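Trimming the Saturated Chain Again: Compound 3

The source may hold more compounds than are shown below. What is called first, only, known or untested is meant among the compounds shown, and "the series" means these compounds.

Among the measured compounds shown here, in a functional assay on MDA-MB-231 cells (Homo sapiens) for cytotoxicity, read by MTT assay, with a stated time of 24 h (on this read-out lower numbers stand for stronger inhibition and higher numbers for weaker inhibition), compound 2 `CCCCCCCC(=O)Nc1nnc(S[C@@H]2O[C@H](CO)[C@H](O)[C@H](O)[C@H]2O)s1` gives 30800 nM, the lower of the two numbers so far, while compound 1 `CCCCCCCCCCCCCCCCCC(=O)Nc1nnc(S[C@@H]2O[C@H](CO)[C@H](O)[C@H](O)[C@H]2O)s1` gives 67100 nM. Compound 3 `CCCCCC(=O)Nc1nnc(S[C@@H]2O[C@H](CO)[C@H](O)[C@H](O)[C@H]2O)s1` shortens the chain again: hydrogen in place of ethyl on a saturated chain carbon, five bonds along the chain from a carbonyl carbon. For the measured compounds named here, the only measured step bearing on this is a 2.2-fold lower number from compound 1 to compound 2 (0.34 log units; beyond the scatter), a modest change for the loss of decyl. Losing only ethyl should move the number less, so the expected step is a 1.2-fold lower number from compound 2 to compound 3 (0.07 log units; within the scatter), within the scatter. Compound 3 is estimated at 26000 nM, with an expected range of 12000 nM to 55000 nM.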

Compound 3, half-maximal inhibitory concentration: 28700 nM
Compound 3: the middle estimate sits 1.1-fold (0.04 log units) below what was measured; the range from low to high includes it.
By their numbers in this assay, from the lowest: compounds 3 and 2 (each within the scatter of the next); then compound 1.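

In this assay the loss of ethyl gives a 1.1-fold lower number from compound 2 to compound 3 (0.03 log units; within the scatter) and so separates compound 2 from compound 3 by no more than the scatter, whereas the loss of dodecyl gives a 2.3-fold lower number from compound 1 to compound 3 (0.37 log units; beyond the scatter) in this comparison. Both steps beyond the scatter therefore start from compound 1, and trimming from compound 2 to compound 3 brings no readable change. No measured evidence explains this result.

As far as these compounds go, what an amine or a carboxylic acid on this chain would do stays open. So does the effect of a chain shorter than that of compound 3.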